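The compounds below may be only part of what the source reports. "The series", "measured", "known", "first", "only" and "open" are said of these compounds alone.

Compound 2, whose structure is `COc1cc(-c2nn(-c3cccc(NC(=O)Nc4cccc(C(F)(F)F)c4)c3)cc2-c2ccncc2)ccc1Cl`, carries a urea that links the shared core to a 3-(trifluoromethyl)phenyl group. Among the measured compounds shown here, in a functional assay on RXF 393 cells (Homo sapiens) for inhibition, read by sulforhodamine B assay, with a stated time of 48 h (on this read-out lower numbers stand for higher toxicity in this test and higher numbers for lower toxicity in this test), compound 2 gives 4830 nM, the only fully determined value in this set. Compound 1, with the structure `O=C(Nc1cccc(-n2cc(-c3ccncc3)c(-c3ccc(Cl)c(O)c3)n2)c1)Nc1ccc(Cl)c(Cl)c1`, has a 3,4-dichlorophenyl group on its urea together with a hydroxy group on its core. In this assay compound 1 reaches only a limit, > 32500 nM, and the record notes (the limit of > 32500 nM in this assay, at which 1 of the 2 values shown sits). Compound 3, with the structure `COc1cc(-c2nn(-c3cccc(NC(=O)Nc4ccc(Cl)c(Cl)c4)c3)cc2-c2ccncc2)ccc1Cl`, has not yet been tested; it is made from compound 2 by a single exchange: 3,4-dichlorophenyl in place of 3-(trifluoromethyl)phenyl on an amide-type nitrogen. Since compound 1 pairs that same 3,4-dichlorophenyl group with a limit while compound 2 pairs the trifluoromethyl group with a number, the step from compound 2 to compound 3 is expected to lose activity, about a 2.5-fold higher number from compound 2 to compound 3 (0.40 log units; beyond the scatter). For compound 3 the estimate in this assay is 12000 nM, within a band from 4000 nM to 40000 nM, and the outcome itself now follows.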

Compound 3, concentration lethal to 50% of the cells: > 50000 nM
Compound 3: no number, only a limit; the forecaster's own chance of this, stated with the estimate: 35%; at least 4.1-fold (0.61 log units) between middle value and limit.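

In this assay, exchanging 3-(trifluoromethyl)phenyl for 3,4-dichlorophenyl on the amide-type nitrogen, with the rest of the molecule unchanged, gives an at least 10-fold higher number from compound 2 to compound 3 (1.01 log units; beyond the scatter). Among the compounds shown here, compound 1 differs from compound 2 in two places, so this is the first comparison that isolates this group, and it shows that this single exchange is enough to move the compound to much lower toxicity in this test. The result for compound 3 is a limit and not a number: the limit of > 50000 nM in this assay, at which 1 of the 3 values shown sits.

Going by these compounds, the step between compound 1 and compound 3 cannot be read, with both at limits, so the effect of methyl in place of hydrogen on that oxygen stays open. Also open, on these data alone, is how a phenyl carrying an amine or a carboxylic acid on this nitrogen would behave in this assay.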